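Opening the ring of compound 2: working notes

This account rests on a few compounds, and the source may have more. Where it says the series, first, only, none or still open, it means among the compounds named here.

In a functional assay on Bel-7402 cells (Homo sapiens) for inhibition, read by MTT assay, with a stated time of 24 h, tested at 1 ug/mL (on this read-out higher numbers stand for more inhibition of growth at the one concentration tested and lower numbers for less inhibition of growth), the series stands as follows:
compound 1 `O=C(CCCCC1CCSS1)NO` gives 7.39% here
compound 2 `O=C(CCCCC1CCSS1)Nc1cccc(C(F)(F)F)c1` gives "not active" (no number reported) here
compound 3 `O=C(CCCCC1CCSS1)Nc1ccc([N+](=O)[O-])c(C(F)(F)F)c1` gives 7.46% here

Compound 2 has no single number in this assay and so offers no measured starting point for a step. Among the measured compounds shown here, no step between measured compounds is available either. Compound 1 at 7.39% and compound 3 at 7.46% lie within the scatter of each other.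

For the measured compounds named here, the one structural change from compound 2 to compound 4 `O=C(CCCCC(S)CCS)Nc1cccc(C(F)(F)F)c1` is a group of 5 heavy atoms (3 carbon, 2 sulfur; no ring) in place of a group of 5 heavy atoms (3 carbon, 2 sulfur; one five-membered non-aromatic ring with 2 hetero atoms), on a saturated chain carbon, four bonds along the chain from a carbonyl carbon and it replaces the five-membered non-aromatic ring with the open 1,3-disulfanylpropyl group. The effect of this change has not been measured anywhere in the series.

No shift beyond the scatter is expected in this assay for this change. Going by the values given here, the expectation rests on compound 1 at 7.39% and compound 3 at 7.46% as the only numbers available. If a shift does appear, a small rise in growth inhibition is the expected direction, and compound 4 could again be reported without a number. For compound 4 the estimated value is 8% with 0% to 22% as the expected range.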

Compound 4, percent growth inhibition at one concentration: 1.66%
Beside the measured number, compound 4's estimate is 6.3 percentage points above it, within the range that was stated.
By their numbers in this assay, from the lowest: compounds 4, 1 and 3 (each within the scatter of the next).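

In this assay, among the compounds shown here, compound 2 gives "not active" (no number reported) and compound 4 gives 1.66%, so no step from compound 2 to compound 4 can be read. As far as these compounds go, whether replacing the ring with the open 1,3-disulfanylpropyl group shifts growth inhibition stays open. No measured evidence bears on the result of compound 4.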